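Lengthening the acid chain from compound 1 to compound 4

A few compounds are considered here, and "the series" means these few. Any claim that something is new, unique, unknown or untested is made for them only; others in the source may bear on it.

For the measured compounds named here, compound 1 `CO[C@H]1C[C@H](Oc2cc(F)c(F)c(-c3cc(F)c(OCCCC(=O)O)c(F)c3)c2)C1` is one of three compounds measured in a functional assay on CHO cells for agonist activity at Free fatty acid receptor 1 (Homo sapiens), read by calcium flux; a higher number here means that more compound is needed for the effect, a lower number that less compound is needed. Compound 1 reaches only the limit of the assay, > 100000 nM. Compound 3 `CO[C@H]1C[C@H](Oc2cc(F)c(F)c(-c3cc(C)c(OCCCC(=O)O)c(C)c3)c2)C1` likewise stops at the limit, > 100000 nM. Compound 2 `CO[C@H]1C[C@H](Oc2ccc([N+](=O)[O-])c(-c3cc(F)c(OCCCC(=O)O)c(F)c3)c2)C1` gives a number, 29400 nM. Compound 1 thus stands at the limit of > 100000 nM in this assay, at which 2 of the 3 values shown sit, without a measured number of its own.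

Compound 4 `CO[C@H]1C[C@H](Oc2cc(F)c(F)c(-c3cc(F)c(OCCCCCC(=O)O)c(F)c3)c2)C1` has not been measured. It differs from compound 1 by 2-carboxyethyl in place of carboxy on a saturated chain carbon, three bonds along the chain from an oxygen on an aromatic ring. Going by the values given here, no step between two measured compounds isolates a change of this kind, so nothing in the measured data fixes its size or direction. With compound 1 already at a limit, the step of a number no higher from compound 1 to compound 4 (the limit leaves the size open) is expected to be none beyond the scatter, and the result is most likely to be reported again as a limit. Compound 4 is estimated at 100000 nM, with a range from 30000 nM to 300000 nM.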

Compound 4, half-maximal effective concentration: 11000 nM
Estimate against measurement, compound 4: 9.1-fold (0.96 log units) above; the whole stated range lies above it.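

Carboxy gives way to 2-carboxyethyl on a saturated chain carbon, three bonds along the chain from an oxygen on an aromatic ring, and this gives an at least 9.0-fold lower number from compound 1 to compound 4 (0.95 log units; beyond the scatter). For the compounds shown here, the three earlier compounds all carry the same acid chain, so only this step shows that the value in this assay responds to a change at this place, and compound 4, at 11000 nM, gives a number on the core of compound 1. The true size of the step stays open, since its starting point is a limit and not a number: the limit of > 100000 nM in this assay, at which 2 of the 4 values shown sit.

The compounds shown do not tell whether a still longer chain would lower the number further, or whether an amide in place of the carboxylic acid would keep the effect. They also leave open whether the longer acid chain would act in the same way alongside the nitro group of compound 2 or the two methyl groups of compound 3.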